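Swapping the Five-Membered Ring for Phenyl at the Core

This account rests on a few compounds, and the source may have more. Where it says the series, first, only, none or still open, it means among the compounds named here.

Compound 3 `O=c1[nH]cnc2c1c(-c1ccco1)cn2[C@@H]1O[C@H](CO)[C@@H](O)[C@H]1O` is the only one of the three measured compounds that yields an actual number in a functional assay on K562 cells (Homo sapiens), read by MTT assay, with a stated time of 72 h; a lower number here means a stronger inhibitor, a higher number a weaker inhibitor: compound 3 gives 15500 nM. Compound 1 `O=c1[nH]cnc2c1c(-c1cccs1)cn2[C@@H]1O[C@H](CO)[C@@H](O)[C@H]1O` reaches only the limit of the assay, > 20000 nM, which is a limit and not a number. Compound 2 `O=c1[nH]cnc2c1c(-c1ccsc1)cn2[C@@H]1O[C@H](CO)[C@@H](O)[C@H]1O` likewise stops at the limit of the assay in this assay, > 20000 nM. Going by the values given here, what the set shows is therefore mostly (the limit of > 20000 nM in this assay, at which 2 of the 3 values shown sit), and compound 3 stands as the sole readable value.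

Compound 4 `O=c1[nH]cnc2c1c(-c1ccccc1)cn2[C@@H]1O[C@H](CO)[C@@H](O)[C@H]1O` differs from compound 3 in one place: phenyl in place of furan-2-yl on an aromatic carbon. The steps already measured at this position are an at least 1.2-fold lower number from compound 1 to compound 3 (0.11 log units; that floor lies within the scatter) and an at least 1.2-fold lower number from compound 2 to compound 3 (0.11 log units; that floor lies within the scatter); both are floors that could be larger, and the step that the two limits leave unreadable from compound 1 to compound 2 cannot be sized at all. Every aryl group tried here gives a weak compound. A phenyl group is expected to leave compound 4 in the same weak range, with a fair chance of falling back to a limit, so the step of a 1.3-fold higher number from compound 3 to compound 4 (0.11 log units; within the scatter) is expected to be small and, if anything, toward a higher number. Compound 4 is therefore estimated at 20000 nM, between 8000 nM and 50000 nM.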

Compound 4, half-maximal inhibitory concentration: > 20000 nM
Compound 4 gave a limit, no number; the forecaster's own chance of this, stated with the estimate: 55%; the middle value sits exactly at the limit.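

With phenyl on this aromatic carbon, compound 4 also ends at a limit of this assay, which is not a number. The change to a six-membered aromatic ring of carbon only gives an at least 1.2-fold higher number from compound 3 to compound 4 (0.11 log units; that floor lies within the scatter); this is only a floor, so a real loss against furan-2-yl is neither shown nor ruled out, and the steps from the two thiophene compounds to compound 4 cannot be read. What compound 4 adds is that the weak outcome at this position is no longer confined to five-membered aromatic rings, and the values now gather even more tightly at one point: the limit of > 20000 nM in this assay, at which 3 of the 4 values shown sit.

Going by these compounds alone, with compound 3 as the only compound giving a number, the data cannot rank these aryl groups against one another. As far as these compounds go, all four groups are plain aromatic rings, so it stays open whether an amine, a longer alkyl chain or a phenyl ring carrying a methoxy group at this position would bring the value into a range that can be read.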